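An Open Chain Gives Way to a Ring

The source may hold more compounds than are shown below. What is called first, only, known or untested is meant among the compounds shown, and "the series" means these compounds.

Measured in a functional assay on L1210 cells (Mus musculus) for inhibition; on this read-out higher numbers stand for weaker inhibition and lower numbers for stronger inhibition:
- Compound 1 `Cc1cn(C/C=C\CCl)c(=O)[nH]c1=O`: 46000 nM
- Compound 2 `Nc1ccn(C=C=CCO)c(=O)n1`: 560000 nM
- Compound 3 `Nc1ncnc2c1ncn2C=C=CCCl`: 45000 nM

Compound 3, at 45000 nM, stands level with compound 1 within the scatter of the measurement. Compound 2 gives a clearly higher number, beyond that scatter, and so inhibits more weakly than compound 3.

The next compound to be tested is compound 4 `Nc1ncnc2c1ncn2C1C=CCO1`. Here the 4-chlorobuta-1,2-dien-1-yl group of compound 3 is replaced, on an aromatic nitrogen, by a five-membered non-aromatic ring with one hetero atom: a group of 5 heavy atoms (4 carbon, 1 oxygen; one five-membered non-aromatic ring with 1 hetero atom) in place of a group of 5 heavy atoms (4 carbon, 1 chlorine; no ring), on an aromatic nitrogen. The chlorine is lost with this change.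

Within the data shown here, no measured pair shows this change on its own, so the evidence is thin. Compound 1 and compound 3 both carry chlorine and give the two lower numbers, while compound 2 has none and stands at 560000 nM, though it also differs elsewhere. On that slim basis, a move toward weaker inhibition in this assay is expected, probably beyond the scatter. The expected change is a 3.3-fold higher number from compound 3 to compound 4 (0.52 log units; beyond the scatter). For compound 4 the estimated value is 150000 nM, with an expected range from 40000 nM to 600000 nM.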

Compound 4, half-maximal inhibitory concentration: > 500000 nM
Compound 4: no number, only a limit (the forecaster's own chance of this, stated with the estimate: 35%); middle value at least 3.3-fold (0.52 log units) from the limit.
By their numbers in this assay, from the lowest: compounds 3 and 1 (each within the scatter of the next); then compound 2.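

Among these compounds, until now, no two compounds differed in one place only, so nothing could be said about any single change. In this assay, replacing the open 4-chlorobuta-1,2-dien-1-yl chain on the aromatic nitrogen with a five-membered non-aromatic ring with one hetero atom gives an at least 11-fold higher number from compound 3 to compound 4 (1.04 log units; beyond the scatter), which shows that inhibition at this position is clearly sensitive to the group it carries, even though both groups have the same count of heavy atoms. Compound 4 reads > 500000 nM, which is a limit of the assay and not a number, so the step gives only the least size of the loss, and the full size stays unknown: the limit of > 500000 nM in this assay, at which 1 of the 4 values shown sits.

The step removes the chlorine, the open chain and its two double bonds and brings in the ring oxygen all at once, so the compounds shown cannot say which of these differences matters on this core. A ring of carbon only, a ring bearing a chloromethyl group, or an open chain ending in an amine on the same core would each help to separate them.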